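A few compounds are considered here, and "the series" means these few. Any claim that something is new, unique, unknown or untested is made for them only; others in the source may bear on it.

Working notes on the series. Compound 3 `COc1ccc2c(=O)c(-c3cc(OC)c(OC)cc3OC)coc2c1` stands at the floor of the set: in a functional assay on HUVEC cells (Homo sapiens) for antiproliferative activity, read by MTT assay, with a stated time of 24 h (on this read-out lower numbers stand for stronger inhibition and higher numbers for weaker inhibition), compound 3 returns only the limit > 10000 nM, not a number, as recorded in the limit of > 10000 nM in this assay, at which 1 of the 3 values shown sits. Compound 1 `COc1cc(OC)c(-c2coc3cc(OCC=C(C)C)ccc3c2=O)cc1OC` gives 3800 nM and compound 2 `COc1cc(OC)c(-c2coc3cc(OCc4ccccc4)ccc3c2=O)cc1OC` gives 9750 nM. Compound 4 `COc1cc(OC)c(-c2coc3cc(OCc4ccccc4F)ccc3c2=O)cc1OC` differs from compound 3 by 2-fluorophenyl in place of hydrogen on a saturated chain carbon bound to an oxygen on an aromatic ring. The bearing steps are an at least 1.0-fold higher number from compound 2 to compound 3 (0.01 log units; that floor lies within the scatter), the reverse of which maps onto the new compound, and an at least 2.6-fold higher number from compound 1 to compound 3 (0.42 log units; beyond the scatter). Since the phenyl analogue compound 2 sits at 9750 nM, compound 4 is expected to land near it, with a step of an at least 1.2-fold lower number from compound 3 to compound 4 (0.09 log units; that floor lies within the scatter) that may only recover a modest gain. Compound 4 is estimated at 8000 nM, range 3000 nM to 25000 nM.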

Compound 4, half-maximal inhibitory concentration: 4300 nM
For compound 4 the middle estimate is 1.9-fold (0.27 log units) above the measured one; low and high end bracket the measured number.
By their numbers in this assay, from the lowest: compounds 1 and 4 (each within the scatter of the next); then compound 2. At a limit, above all of these: compound 3.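

Fluoro in place of hydrogen on an aromatic carbon gives a 2.3-fold lower number from compound 2 to compound 4 (0.36 log units; beyond the scatter), and 2-fluorophenyl on the saturated chain carbon gives an at least 2.3-fold lower number from compound 3 to compound 4 (0.36 log units; beyond the scatter), a floor beyond the scatter that the unsubstituted phenyl of compound 2 did not show. Against the 2-methylprop-1-en-1-yl group the aromatic group now gives a 1.1-fold higher number from compound 1 to compound 4 (0.05 log units; within the scatter). Compound 3 remains a limit, not a number: the limit of > 10000 nM in this assay, at which 1 of the 4 values shown sits.

Open, as far as these compounds go, is whether chloro or methoxy in place of the fluoro gives the same gain. Also open, from the compounds shown here alone, is how 3-fluorophenyl or 4-fluorophenyl compares with 2-fluorophenyl.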